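The compounds below may be only part of what the source reports. "The series", "measured", "known", "first", "only" and "open" are said of these compounds alone.

Measured so far in an assay on isolated protein for inhibition of histone deacetylase 4 (Homo sapiens), with a stated time of 1 h; on this read-out lower numbers stand for stronger inhibition and higher numbers for weaker inhibition:
- compound 1 `O=C(COc1ccc2cc(/C=C3/SC(=O)NC3=O)ccc2c1)Nc1ccc(Br)cc1F`: 1900 nM
- compound 2 `Cc1cccc2sc(NC(=O)COc3ccc4cc(/C=C5/SC(=O)NC5=O)ccc4c3)nc12`: 1200 nM

Compound 2 carries the lowest of the two numbers, but its separation from compound 1 is a 1.6-fold lower number from compound 1 to compound 2 (0.20 log units; within the scatter), so the two stand within the scatter of each other and no order between them is claimed.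

Compound 3 `O=C(COc1ccc2cc(/C=C3/SC(=O)NC3=O)ccc2c1)Nc1ccc(Br)cc1` is not yet measured. Its change from compound 2 is 4-bromophenyl in place of 4-methyl-1,3-benzothiazol-2-yl on an amide-type nitrogen. Going by the values given here, the only step that bears on it is the one from compound 1 to compound 2, where 4-methyl-1,3-benzothiazol-2-yl replaced 4-bromo-2-fluorophenyl on the amide-type nitrogen, a step of a 1.6-fold lower number from compound 1 to compound 2 (0.20 log units; within the scatter). Compound 1, with 4-bromo-2-fluorophenyl on that nitrogen, is the closer structural neighbour of compound 3 among the measured pair, and both measured numbers lie close together. For compound 3 in this assay a step of a 1.3-fold higher number from compound 2 to compound 3 (0.12 log units; within the scatter) is therefore expected, no more than the scatter. The estimate for compound 3 is 1600 nM, within 700 nM to 3600 nM.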

Compound 3, half-maximal inhibitory concentration: 2900 nM
Beside the measured number, compound 3's estimate is 1.8-fold (0.26 log units) below it; measured number inside the range.
By their numbers in this assay, from the lowest: compounds 2, 1 and 3 (each within the scatter of the next, the first and the last beyond it).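

In this assay, going by these compounds alone, the exchange on the amide-type nitrogen gives the only step beyond the scatter (a 2.4-fold higher number from compound 2 to compound 3 (0.38 log units; beyond the scatter)), so 4-methyl-1,3-benzothiazol-2-yl and 4-bromophenyl can be told apart at this position, though only modestly. Fluoro and hydrogen on the aromatic carbon cannot be told apart (a 1.5-fold higher number from compound 1 to compound 3 (0.18 log units; within the scatter)), and because compound 1 also lies within the scatter of compound 2, the separation holds for the pair of compound 2 and compound 3 alone. Nothing measured accounts for the gap between these two groups on that nitrogen.

Still open, from the compounds shown here alone, is whether an amine or a carboxylic acid in place of the bromine on the phenyl ring would move the number at all. Also open, going by these compounds, is whether 1,3-benzothiazol-2-yl without its 4-methyl group would stay level with compound 2.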